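Adding a phenyl to an amide in a glucose-based inhibitor

The source may hold more compounds than are shown below. What is called first, only, known or untested is meant among the compounds shown, and "the series" means these compounds.

Measured compounds:
- compound 1, `NC(=O)CS[C@H]1O[C@H](CO)[C@@H](O)[C@H](O)[C@H]1O`, gives 20000000 nM in an assay on isolated protein (Sus scrofa) for inhibition of glycogen phosphorylase, brain form (Homo sapiens); a higher number here means a weaker inhibitor, a lower number a stronger inhibitor
- compound 2, `NC(=O)N[C@H]1O[C@H](CO)[C@@H](O)[C@H](O)[C@H]1O`, gives 126000 nM in this assay
- compound 3, `CNNC(=O)[C@H]1O[C@H](CO)[C@@H](O)[C@H](O)[C@H]1O`, gives 2000000 nM in this assay

Compound 1 has the highest number of the three, so it is the weakest inhibitor shown; the nearest is compound 3, with a 10-fold lower number from compound 1 to compound 3 (1.00 log units; beyond the scatter), and the furthest is compound 2, with a 160-fold lower number from compound 1 to compound 2 (2.20 log units; beyond the scatter). Compound 4, `O=C(CS[C@H]1O[C@H](CO)[C@@H](O)[C@H](O)[C@H]1O)Nc1ccccc1`, differs from compound 1 by phenyl in place of hydrogen on an amide-type nitrogen.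

Going by the values given here, none of the measured steps bears directly on this change: the steps between compound 1, compound 2 and compound 3, including a 16-fold higher number from compound 2 to compound 3 (1.20 log units; beyond the scatter), all replace the whole group on the saturated ring carbon, while compound 4 keeps that group and alters only the amide nitrogen. The expectation therefore rests on compound 1 alone, and a modest change in either direction cannot be ruled out.

Compound 4 is estimated at 4000000 nM, within 400000 nM to 30000000 nM, which corresponds to an expected step of a 5.0-fold lower number from compound 1 to compound 4 (0.70 log units; beyond the scatter).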

Compound 4, inhibition constant: 3980000 nM
Estimate against measurement, compound 4: 1.0-fold (0.00 log units) above, and the stated range covers the measured number.
By their numbers in this assay, from the lowest: compound 2; then compounds 3 and 4 (each within the scatter of the next); then compound 1.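

Going by these compounds alone, compound 4 gives the first reading on the amide nitrogen itself: with the rest of compound 1 unchanged, amino to anilino gives a 5.0-fold lower number from compound 1 to compound 4 (0.70 log units; beyond the scatter) in this assay. This nitrogen therefore accepts a phenyl in place of hydrogen, and inhibition becomes modestly stronger rather than being lost. Nothing shown here accounts for this step.

As far as these compounds go, it remains open whether a benzyl, a longer chain ending in phenyl, or a phenyl carrying chlorine or methoxy would lower the number further. From the compounds shown here alone, whether a phenyl on the ureido group of compound 2 would have a similar effect is also open.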